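Pyrrolidin-1-yl gives way to isobutylamino on the shared core

The source may report more compounds than this note shows. Statements on the series, on what has been measured and on what is new or still open speak of the compounds shown alone.

Compound 1 `CCCSc1nc(N)nc2c1ncn2/C=C1/CC1(CO)CO`: 98000 nM
Compound 2 `CC(C)Nc1nc(N)nc2c1ncn2/C=C1/CC1(CO)CO`: > 20000 nM
Compound 3 `Nc1nc(N2CCCC2)c2ncn(/C=C3/CC3(CO)CO)c2n1`: > 20000 nM

These values come from an ADME assay on CCRF-HSB-2 cells (Homo sapiens) for cytotoxicity, with a stated time of 7 days; on this read-out higher numbers stand for lower toxicity in this test and lower numbers for higher toxicity in this test. Compound 3 gives no number, only a limit, > 20000 nM. Compound 2 likewise gives only a limit, > 20000 nM. Compound 3 therefore stands at the limit of > 20000 nM in this assay, at which 2 of the 3 values shown sit. Only compound 1, at 98000 nM, has a true number.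

Compound 4 `CC(C)CNc1nc(N)nc2c1ncn2/C=C1/CC1(CO)CO` carries isobutylamino in place of pyrrolidin-1-yl on an aromatic carbon. Three measured steps change the same carbon: a step that the two limits leave unreadable from compound 2 to compound 3, a step that the limit leaves unreadable from compound 1 to compound 2 and a step that the limit leaves unreadable from compound 1 to compound 3. None of them has a readable size, so they give no ground for expecting a shift in either direction, and no change beyond the scatter is expected. The step expected is a step that the limit leaves unreadable from compound 3 to compound 4. The assay may well report only a limit again. Compound 4 is estimated at 40000 nM, with an expected range from 18000 nM to 100000 nM.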

Compound 4, half-maximal cytotoxic concentration: > 20000 nM
Compound 4 gave a limit, no number (the forecaster's own chance of this, stated with the estimate: 70%); the middle value is on the limit's open side.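

Going by these compounds alone, compound 4 returns only a limit, so no step linking it to compound 1, compound 2 or compound 3 can be read: the limit of > 20000 nM in this assay, at which 3 of the 4 values shown sit.

In this assay the compounds shown leave open whether compound 2, compound 3 and compound 4 differ from one another at all.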